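The source may report more compounds than this note shows. Statements on the series, on what has been measured and on what is new or still open speak of the compounds shown alone.

The measured compounds:
Compound 1, `COCc1ccccc1Cc1cnc(N)nc1N`, gives 39800 nM in an assay for inhibition of Dihydrofolate reductase (Gallus gallus); on this read-out higher numbers stand for weaker inhibition and lower numbers for stronger inhibition.
Compound 2, `NC(=O)COc1ccccc1Cc1cnc(N)nc1N`, gives 33900 nM in this assay.

For the measured compounds named here, with only two numbers so far, compound 2 stands alongside compound 1, and the gap between them is within the scatter: a 1.2-fold lower number from compound 1 to compound 2 (0.07 log units; within the scatter). The two compounds therefore cannot be set apart on this read-out. Compound 3, `Nc1ncc(Cc2ccccc2F)c(N)n1`, has not been measured. It differs from compound 2 in one place: fluoro in place of carbamoylmethoxy on an aromatic carbon. The change sits on an aromatic carbon of a six-membered aromatic ring of carbon only, ortho to a group of 9 heavy atoms. Going by the values given here, only one measured step touches this place: a 1.2-fold lower number from compound 1 to compound 2 (0.07 log units; within the scatter), in which one group was exchanged for another without moving the number beyond the scatter. Among the compounds with values here, the step to compound 3 is of a different kind, replacing the whole carbamoylmethoxy group with fluoro, and no measured pair covers such a change. On this thin basis no step beyond the scatter is expected in either direction, but the range must stay wide. Compound 3 is therefore estimated at 32000 nM, between 8000 nM and 130000 nM, an expected step of a 1.1-fold lower number from compound 2 to compound 3 (0.03 log units; within the scatter).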

Compound 3, inhibition constant: 43700 nM
Beside the measured number, compound 3's estimate is 1.4-fold (0.14 log units) below it; low and high end bracket the measured number.
By their numbers in this assay, from the lowest: compounds 2, 1 and 3 (each within the scatter of the next).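

In this assay, the exchange of carbamoylmethoxy, with 5 heavy atoms, for fluoro, with 1 heavy atom, gives a 1.3-fold higher number from compound 2 to compound 3 (0.11 log units; within the scatter) at this aromatic carbon, and the exchange of methoxymethyl for fluoro gives a 1.1-fold higher number from compound 1 to compound 3 (0.04 log units; within the scatter) at the same place. For the compounds shown here, compounds 1 and 2 compared only two groups built of several atoms, whereas compound 3 shows that a single fluorine, with 0 hydrogen-bond donors and 0 hydrogen-bond acceptors, also cannot be set apart from either of them on this read-out. Among these three compounds, then, neither the number of heavy atoms in the group nor its count of hydrogen-bond donors and acceptors goes with a step beyond the scatter, and no outside measurement bears on why the numbers lie so close together.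

On these data alone, whether an amine, a carboxylic acid or a longer chain at this place would stay within the scatter of these three numbers remains open, as does the result with a plain hydrogen there. Also open, as far as these compounds go, is whether any change to the shared core would give a step beyond the scatter.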